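Amide linker variation in a thiosemicarbazide series

This account rests on a few compounds, and the source may have more. Where it says the series, first, only, none or still open, it means among the compounds named here.

Compound 1 `O=C(COc1ccccc1)NNC(=S)NCc1ccc(-c2ccccc2)cc1` gives 10000 nM in an assay on isolated protein for inhibition of A disintegrin and metalloproteinase with thrombospondin motifs 5 (Homo sapiens), read by spectrophotometry, with stated times of 10 min and 3 h; a higher number here means a weaker inhibitor, a lower number a stronger inhibitor; compound 2 `O=C(COc1ccc(Cl)c(Cl)c1)NNC(=S)NCc1ccc(-c2ccccc2)cc1` gives 1200 nM; compound 3 `O=C(NNC(=S)NCc1ccc(-c2ccccc2)cc1)c1ccc(Cl)cc1` gives 700 nM.

Compound 3 has the lowest of the three numbers, though its gap to compound 2 is within the scatter (a 1.7-fold lower number from compound 2 to compound 3 (0.23 log units; within the scatter)), while the other gap is clear (a 14-fold lower number from compound 1 to compound 3 (1.15 log units; beyond the scatter)). Compound 4 `O=C(CNc1ccc(Cl)cc1)NNC(=S)NCc1ccc(-c2ccccc2)cc1` is compound 3 with ((4-chlorophenyl)amino)methyl in place of 4-chlorophenyl on a carbonyl carbon. Among the compounds with values here, this largely reverses the one earlier step at that carbonyl carbon, where an aryl-linked methylene gave way to a directly attached ring (a 14-fold lower number from compound 1 to compound 3 (1.15 log units; beyond the scatter)); the aryl-linked methylene of compound 2 sat close to compound 3. A modest rise is therefore expected, a 1.9-fold higher number from compound 3 to compound 4 (0.27 log units; within the scatter). Compound 4 is estimated at 1300 nM, with a range of 500 nM to 3500 nM.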

Compound 4, half-maximal inhibitory concentration: 6300 nM
Compound 4: the middle estimate sits 4.8-fold (0.69 log units) below what was measured; the measured number lies above the stated range.
By their numbers in this assay, from the lowest: compounds 3 and 2 (each within the scatter of the next); then compounds 4 and 1 (each within the scatter of the next).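

On the carbonyl carbon, ((4-chlorophenyl)amino)methyl does not stand in for the directly attached 4-chlorophenyl in this assay (a 9.0-fold higher number from compound 3 to compound 4 (0.95 log units; beyond the scatter)). It also falls short of the 3,4-dichlorophenoxy chain (a 5.3-fold higher number from compound 2 to compound 4 (0.72 log units; beyond the scatter)), so an aryl-linked methylene alone does not keep a low number. Against the phenoxy chain, (4-chlorophenyl)amino gives no clear change (a 1.6-fold lower number from compound 1 to compound 4 (0.20 log units; within the scatter)).

No evidence in hand accounts for these steps. As far as these compounds go, whether a (4-chlorophenoxy)methyl group or a longer chain would sit nearer compound 3 or compound 4 remains open.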